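The compounds below may be only part of what the source reports. "The series", "measured", "known", "first", "only" and "open" are said of these compounds alone.

Measured so far:
- Compound 1 `CCCCc1cc2nn(-c3ccccc3)cc2cn1` gives 13300 nM in a functional assay on MCF7 cells (Homo sapiens) for inhibition, read by fluorescence, with a stated time of 72 h; on this read-out lower numbers stand for stronger inhibition of growth and higher numbers for weaker inhibition of growth.
- Compound 2 `Cc1nc(-c2ccsc2)cc2nn(-c3ccccc3)cc12` gives 22200 nM in this assay.

Compound 2 and compound 1 sit within the usual scatter of each other, so neither is separated from the other. Compound 3 `CCCCc1cc2nn(-c3ccccc3)cc2c(C)n1` differs from compound 2 by butyl in place of thiophen-3-yl on an aromatic carbon. Compound 3 also shares the butyl of compound 1. Because compound 1 gives 13300 nM, compound 3 is expected to land close to it, and the step of a 1.6-fold lower number from compound 2 to compound 3 (0.20 log units; within the scatter) is estimated to stay within the scatter. Compound 3 is therefore expected to give 14000 nM, with a range of 5000 nM to 40000 nM.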

Compound 3, concentration for 50% growth inhibition: 11100 nM
For compound 3 the middle estimate is 1.3-fold (0.10 log units) above the measured one, and the stated range covers the measured number.
By their numbers in this assay, from the lowest: compounds 3, 1 and 2 (each within the scatter of the next).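

In this assay, butyl in place of thiophen-3-yl, next to the ring nitrogen, gives a 2.0-fold lower number from compound 2 to compound 3 (0.30 log units; within the scatter), so replacing this ring with an open chain does not separate the two compounds. Methyl in place of hydrogen on an aromatic carbon gives a 1.2-fold lower number from compound 1 to compound 3 (0.08 log units; within the scatter), so these two compounds are not separated either. No other measurement here helps to explain these results. Still open, on these data alone, is whether an amine, a carboxylic acid or a chain longer than butyl at the thiophen-3-yl position would give a number beyond the scatter.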